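The source may report more compounds than this note shows. Statements on the series, on what has been measured and on what is new or still open speak of the compounds shown alone.

Compound 1 `COc1ccc(C2SCC(=O)N2CCN2CCCCC2)cc1` was examined in an ADME assay on Vero cells (Chlorocebus sabaeus) for cytotoxicity, read by neutral red uptake, tested at 12.3 ug/mL (a higher number here means a weaker effect of the compound at the concentration tested, a lower number a stronger effect), and in this assay compound 1 gives 100%. Compound 2 `O=C1CSC(c2ccccc2[N+](=O)[O-])N1CCN1CCCCC1`, which shares the same core, gives 100% in this assay, level with compound 1 within the scatter. Compound 3 `O=C1CSC(c2ccc(F)cc2)N1CCN1CCCCC1` is not yet measured and differs from compound 1 by fluoro in place of methoxy on an aromatic carbon. Among the compounds with values here, no measured pair shows this change here. Because compound 1 stands at 100%, the step is expected to be a number 2 percentage points lower from compound 1 to compound 3 (within the scatter) in this assay, none beyond the scatter. Compound 3 is estimated at 98%, with a range from 85% to 105%.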

Compound 3, a percentage reported as activity, at one concentration (the size of the read-out at that concentration, not a potency): 100%
The estimate for compound 3 lay 2 percentage points below the measured number; low and high end bracket the measured number.
By their numbers in this assay, from the lowest: compounds 1, 2 and 3 (each within the scatter of the next).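

In this assay, exchanging methoxy for fluoro on an aromatic carbon para to a large group gives no change at the digits printed from compound 1 to compound 3 (within the scatter). Within the data shown here, this is the first direct comparison at this position, and it shows that replacing this group with a smaller one, with one heavy atom rather than two, leaves the read-out unmoved. No measurement available here explains this result. Still open, from the compounds shown here alone, is whether any group at this position can shift the read-out, such as an amine or a carboxylic acid.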